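Swapping a Nitro for a Methyl on a Shared Core

The source may report more compounds than this note shows. Statements on the series, on what has been measured and on what is new or still open speak of the compounds shown alone.

Two compounds share one core and differ only in the group on the six-membered aromatic ring of carbon only. Compound 1 `O=C1CSC(c2ccc(O)cc2)N1CCN1CCCCC1` carries a hydroxy there, and in an ADME assay on Vero cells (Chlorocebus sabaeus) for cytotoxicity, read by neutral red uptake, tested at 787 ug/mL (a higher number here means a weaker effect of the compound at the concentration tested, a lower number a stronger effect), compound 1 gives 57%. Compound 2 `O=C1CSC(c2ccc([N+](=O)[O-])cc2)N1CCN1CCCCC1` carries a nitro in the same place, and in this assay compound 2 gives 21%. For the measured compounds named here, the step of a number 36 percentage points lower from compound 1 to compound 2 (beyond the scatter) is the only measured step so far, and it is large. Among the two numbers known, compound 2 stands lowest, with compound 1 as its only neighbour, beyond the scatter above it.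

Compound 3 `Cc1ccc(C2SCC(=O)N2CCN2CCCCC2)cc1` has not been measured. Its change from compound 2 is methyl in place of nitro on an aromatic carbon. Going by the values given here, no measured step involves a methyl, so the hydroxy-to-nitro step shows only that a change at this position can move the read-out strongly; the direction for a methyl is open. A moderate rise in this assay is expected, with wide uncertainty. For compound 3 the expected value in this assay is 35%, within a range from 15% to 60%. That amounts to an expected step of a number 14 percentage points higher from compound 2 to compound 3 (beyond the scatter).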

Compound 3, a percentage reported as activity, at one concentration (the size of the read-out at that concentration, not a potency): 17%
Compound 3: middle estimate off by 18 percentage points, on the high side; the range from low to high includes it.
By their numbers in this assay, from the lowest: compounds 3 and 2 (each within the scatter of the next); then compound 1.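

In this assay the exchange of nitro for methyl gives a number 4 percentage points lower from compound 2 to compound 3 (within the scatter), so at this place, on an aromatic carbon para to a large group, the read-out does not separate these two groups. That holds even though nitro brings 3 heavy atoms and 2 hydrogen-bond acceptors, while methyl brings 1 heavy atom and no hydrogen-bond acceptors. The other new comparison gives a number 40 percentage points lower from compound 1 to compound 3 (beyond the scatter), so the large step seen earlier is not particular to nitro, and among these three compounds hydroxy alone stands apart; nothing at hand explains why this group differs from the other two.

An amine or a carboxylic acid on the same aromatic carbon could show whether the higher number in this assay belongs to hydroxy alone or is shared with other groups. A longer chain in place of methyl could show whether the number stays close to those of compound 2 and compound 3 or moves away from them.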